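The source may hold more compounds than are shown below. What is called first, only, known or untested is meant among the compounds shown, and "the series" means these compounds.

Measured compounds and values:

Compound 1 `Cc1nnsc1CO/N=C/c1c(C)nn(C)c1Oc1ccccc1Cl`. In a functional assay on SGC-7901 cells (Homo sapiens) for inhibition, read by MTT assay, with a stated time of 48 h (on this read-out higher numbers stand for weaker inhibition and lower numbers for stronger inhibition), compound 1 reaches only a limit of the assay, > 50000 nM.
Compound 2 `Cc1nnsc1CO/N=C/c1c(C)nn(C)c1Oc1cccc(F)c1`. In this assay compound 2 reaches only a limit of the assay, > 50000 nM.
Compound 3 `Cc1nnsc1CO/N=C/c1c(C)nn(C)c1Oc1ccc(F)cc1`. In this assay compound 3 reaches only a limit of the assay, > 50000 nM.

Compound 3 therefore stands nowhere on a scale of numbers: all three values sit at the limit of > 50000 nM in this assay, at which 3 of the 3 values shown sit, and none of the three is distinguishable from the others. The steps a step that the two limits leave unreadable from compound 1 to compound 2, a step that the two limits leave unreadable from compound 1 to compound 3 and a step that the two limits leave unreadable from compound 2 to compound 3 are unreadable for that reason, both ends of each being a limit.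

Compound 4 `Cc1nnsc1CO/N=C/c1c(C)nn(C)c1Oc1ccc(Br)cc1` differs from compound 3 by bromo in place of fluoro on an aromatic carbon. For the measured compounds named here, no measured step carries this change or anything resembling it, and the three steps that exist give no size at all. With nothing to lean on beyond three limits, compound 4 is estimated at 60000 nM, within 20000 nM to 200000 nM, and most probably again only a limit. The step from compound 3 to compound 4 is expected to be a step that the limit leaves unreadable from compound 3 to compound 4, which is to say no readable step.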

Compound 4, half-maximal inhibitory concentration: 15200 nM
Compound 4: middle estimate off by 3.9-fold (0.60 log units), on the high side; the measured number lies below the stated range.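

In this assay, for the compounds shown here, bromo in place of fluoro on the aromatic carbon para to a large group gives an at least 3.2-fold lower number from compound 3 to compound 4 (0.51 log units; beyond the scatter), so this position responds to a change of halogen, which the earlier compounds could not show. Going by these compounds, the 4-bromophenyl group also separates from the other two aryl groups, with an at least 3.2-fold lower number from compound 2 to compound 4 (0.51 log units; beyond the scatter) and an at least 3.2-fold lower number from compound 1 to compound 4 (0.51 log units; beyond the scatter), and each of these steps has a limit at one end, so its true size is unknown. The steps among compound 1, compound 2 and compound 3 cannot be read, and compound 4 alone carries a number: the limit of > 50000 nM in this assay, at which 3 of the 4 values shown sit.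

On these data alone, whether chloro, iodo, methoxy or an amine at the same place would also give a readable number remains open. Also open, as far as these compounds go, is whether bromo elsewhere on the ring would do the same.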